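Lengthening the Unsaturated Side Chain of Compound 1

The source may report more compounds than this note shows. Statements on the series, on what has been measured and on what is new or still open speak of the compounds shown alone.

Of the compounds shown here, three have been tested in a functional assay on HCT-116 cells (Homo sapiens) for cytotoxicity, read by sulforhodamine B assay, with a stated time of 24 h; a higher number here means a weaker inhibitor, a lower number a stronger inhibitor. Compound 1, `C/C=C(\C)C(=O)Nc1ccn([C@H]2CC[C@H](O[C@H]3O[C@H](C)[C@@H](N(C)C)[C@H](O)[C@H]3O)[C@@H](C)O2)c(=O)n1`, carries a short branched unsaturated amide on the shared core and is the only one of the three to return a number: in this assay compound 1 gives 6450 nM. Compound 2, `CC(=O)C(C)Nc1ccc(C(=O)Nc2ccn([C@H]3CC[C@H](O)[C@@H](C)O3)c(=O)n2)cc1`, is built on a simpler version of the core and reaches only a limit of the assay, > 20000 nM. Compound 3, `CC(C)=CCC(=O)Nc1ccn([C@H]2CC[C@H](O)[C@@H](C)O2)c(=O)n1`, also stops at a limit of the assay, > 20000 nM. Two of the three readings thus sit at the limit of > 20000 nM in this assay, at which 2 of the 3 values shown sit, and compound 1 alone offers a measurable value to build on.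

The unmeasured compound 4, `CC(C)/C=C/C(=O)Nc1ccn([C@H]2CC[C@H](O[C@H]3O[C@H](C)[C@@H](N(C)C)[C@H](O)[C@H]3O)[C@@H](C)O2)c(=O)n1`, keeps everything of compound 1 except the group on the carbonyl carbon: 3-methylbut-1-en-1-yl in place of 1-methylprop-1-en-1-yl on a carbonyl carbon. Within the data shown here, no measured pair of compounds shows a change of this kind, so nothing here sets its size or direction. Both groups are small unsaturated carbon chains, and the rest of the molecule, including the second ring that compounds 2 and 3 lack, is unchanged. The step of a 1.0-fold higher number from compound 1 to compound 4 (0.00 log units; within the scatter) is therefore expected to stay within the usual scatter, with no clear direction. Compound 4 is estimated at 6500 nM, with a plausible range from 2500 nM to 16000 nM.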

Compound 4, half-maximal inhibitory concentration: 780 nM
For compound 4 the middle estimate is 8.3-fold (0.92 log units) above the measured one; measured number below the stated range.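

Swapping 1-methylprop-1-en-1-yl for 3-methylbut-1-en-1-yl on a carbonyl carbon gives an 8.3-fold lower number from compound 1 to compound 4 (0.92 log units; beyond the scatter), a step beyond the usual scatter. Among these compounds, this is the first readable evidence that the group at this place matters to the cytotoxicity read-out when the rest of the molecule stays the same. The change is also a narrow one: the group goes from 4 carbons to 5, while both groups have one double bond, no ring, no hydrogen-bond donors or acceptors and no net charge, so a rearrangement and small extension of a carbon chain is enough to produce a clear step.

Among the compounds shown here, compound 2 and compound 3 each stop at a limit of the assay, and neither differs from compound 4 in only one place, so they add no second step at this position: the limit of > 20000 nM in this assay, at which 2 of the 4 values shown sit. With a single pair, the extra carbon and the altered branching and double-bond placement cannot be separated, and it remains open how a fully saturated pentyl chain, a longer alkenyl chain, a phenyl ring or a chain ending in an amine would behave here.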